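Replacing methoxy with fluoro in compound 2

The source may report more compounds than this note shows. Statements on the series, on what has been measured and on what is new or still open speak of the compounds shown alone.

Compound 1 `Nc1ccccc1NC(=O)/C=C/c1ccc(CSc2ccc(Cl)cc2)cc1` with 15.2% measured
Compound 2 `COc1ccc(SCc2ccc(C(=O)Nc3ccccc3N)cc2)cc1` with 33.1% measured
Compound 3 `COc1ccc(SCc2ccc(C(=O)Nc3ccccc3N)cc2)cc1OC` with 20.2% measured

These values come from a functional assay on SMMC-7721 cells (Homo sapiens) for inhibition, read by CCK-8 assay, with a stated time of 72 h, tested at 2 uM (on this read-out lower numbers stand for less inhibition of growth and higher numbers for more inhibition of growth at the one concentration tested), and they place compound 2 highest of the three, with compound 1 and compound 3 both lower by more than the scatter. The unmeasured compound 4 `Nc1ccccc1NC(=O)c1ccc(CSc2ccc(F)cc2)cc1` departs from compound 2 at one place: fluoro in place of methoxy on an aromatic carbon which amounts to fluoro in place of methoxy on an aromatic carbon, para to a large group.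

Within the data shown here, no measured pair shows this exchange directly. The nearest evidence is the step of a number 12.9 percentage points lower from compound 2 to compound 3 (beyond the scatter) in which methoxy took the place of hydrogen on an aromatic carbon, and that step leaves the methoxy of compound 2 in place. Compound 1 with 15.2% also carries a halogen but differs elsewhere as well, so it offers little guidance. Starting from the top of this small set, a fall is thought likelier than a rise, though it may not clear the scatter. The expected change in this assay is small and downward, estimated as a number 6.1 percentage points lower from compound 2 to compound 4 (within the scatter) for now. For compound 4 the estimated value is 27% with an expected range from 13% to 43% in this reading.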

Compound 4, percent growth inhibition at one concentration: 6.58%
For compound 4 the middle estimate is 20.4 percentage points above the measured one, outside the stated range (below it).
By their numbers in this assay, from the lowest: compounds 4, 1 and 3 (each within the scatter of the next, the first and the last beyond it); then compound 2.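

In this assay, among these compounds, replacing the 4-methoxyphenyl with a 4-fluorophenyl gives a number 26.5 percentage points lower from compound 2 to compound 4 (beyond the scatter), the first direct reading of a change at this position, as the earlier step to compound 3 left this methoxy in place. Among the compounds shown here, the position para to a large group is therefore not indifferent to what it carries: with the rest of the structure unchanged, compound 2 with its methoxy shows clearly more inhibition of growth at the one concentration tested than compound 4 with its fluoro. Nothing shown here accounts for the drop, and the data cannot separate the loss of the methoxy from the arrival of the fluoro.

The compounds shown leave open how this position would read with an amine, a carboxylic acid or a longer chain such as ethoxy, so a single exchange cannot tell whether the methoxy is unusually favourable or the fluoro unusually poor. They also leave open whether the gap between compound 2 and compound 4 would persist at other concentrations, as each compound is represented by one reading at a single concentration.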